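Methyl for chloro on a pair at the assay limit

A few compounds are considered here, and "the series" means these few. Any claim that something is new, unique, unknown or untested is made for them only; others in the source may bear on it.

Measured compounds:
compound 1 `Cc1nnc(SCc2ccccc2)n1N1C(=O)c2ccccc2C1=O` in a functional assay on MKN-45 cells (Homo sapiens) for cytotoxicity, read by MTT assay, with a stated time of 48 h; a higher number here means a weaker inhibitor, a lower number a stronger inhibitor: > 200000 nM
compound 2 `Cc1nnc(SCC(=O)c2ccc(Cl)cc2)n1N1C(=O)c2ccccc2C1=O` in this assay: > 200000 nM

In this assay compound 1 gives > 200000 nM, which is a limit of the assay and not a number. In this assay compound 2 likewise gives > 200000 nM, again a limit. The step that the two limits leave unreadable from compound 1 to compound 2 is therefore unreadable. For the measured compounds named here, compound 2 thus stands only at a limit, and the one other value shown is the same limit, (the limit of > 200000 nM in this assay, at which 2 of the 2 values shown sit).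

Compound 3 `Cc1ccc(C(=O)CSc2nnc(C)n2N2C(=O)c3ccccc3C2=O)cc1` differs from compound 2 in one place: methyl in place of chloro on an aromatic carbon. Going by the values given here, no measured step bears on this change; the sole step between measured compounds, a step that the two limits leave unreadable from compound 1 to compound 2, cannot be sized, and both values sit at the limit of > 200000 nM in this assay, at which 2 of the 2 values shown sit. With nothing to set against the scatter, the expected step of a number no higher from compound 2 to compound 3 (the limit leaves the size open) is none beyond it. Compound 3 is therefore expected at 200000 nM, within 100000 nM to 600000 nM, most likely reported again only as a limit.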

Compound 3, half-maximal inhibitory concentration: > 200000 nM
Compound 3: only a limit was reported; the forecaster's own chance of this, stated with the estimate: 80%; the middle value sits exactly at the limit.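

Compound 3 gives > 200000 nM in this assay, again a limit of the assay and not a number, so neither its step from compound 2 nor its step from compound 1 can be read: the limit of > 200000 nM in this assay, at which 3 of the 3 values shown sit.

The compounds shown leave open what the true values of compound 1, compound 2 and compound 3 are, and whether methyl in place of chloro changes anything.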